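This account rests on a few compounds, and the source may have more. Where it says the series, first, only, none or still open, it means among the compounds named here.

Compound 3, `COc1ccc(C(=O)CSc2nnc(-c3cc(OC)c(OC)c(OC)c3)n2N)cc1`, is the starting point of this step. In a functional assay on HepG2 cells (Homo sapiens) for antiproliferative activity, read by MTT assay, with a stated time of 48 h (on this read-out higher numbers stand for weaker inhibition and lower numbers for stronger inhibition), compound 3 gives only a limit of the assay, > 100000 nM. Its two measured relatives carry other groups on the same carbonyl carbon. Compound 1 is `COc1cc(-c2nnc(SCC(=O)c3ccc(C)cc3)n2N)cc(OC)c1OC`. In this assay compound 1 also reaches only a limit, > 100000 nM. Within the data shown here, compound 2 is `COc1cc(-c2nnc(SCC(=O)c3cccc(Br)c3)n2N)cc(OC)c1OC`, and in this assay compound 2 gives 56000 nM, the one numerical value among the three; this is the situation described by the limit of > 100000 nM in this assay, at which 2 of the 3 values shown sit.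

The two steps that swap the aryl group on the carbonyl carbon are an at least 1.7-fold lower number from compound 1 to compound 2 (0.25 log units; that floor lies within the scatter) and an at least 1.7-fold higher number from compound 2 to compound 3 (0.25 log units; that floor lies within the scatter). The remaining step, a step that the two limits leave unreadable from compound 1 to compound 3, gives no readable size. Compound 4 is `COc1cc(-c2nnc(SCC(=O)Nc3ccccc3C)n2N)cc(OC)c1OC`; it differs from compound 3 by (2-methylphenyl)amino in place of 4-methoxyphenyl on a carbonyl carbon, a change at the same carbonyl carbon as the two readable steps, but one that also replaces the ketone with an amide linkage.

Because the two readable steps at that carbon have floors within the scatter, and because two of the three values sit at the limit recorded in the limit of > 100000 nM in this assay, at which 2 of the 3 values shown sit, compound 4 is expected to stay weak in this assay, with an expected step of an at least 1.1-fold lower number from compound 3 to compound 4 (0.04 log units; that floor lies within the scatter). The estimate for compound 4 is 90000 nM, with a range from 30000 nM to 300000 nM.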

Compound 4, half-maximal inhibitory concentration: > 100000 nM
Compound 4 gave a limit, no number (the forecaster's own chance of this, stated with the estimate: 50%); middle value at least 1.1-fold (0.04 log units) away from the limit.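

Compound 4 shows that this carbonyl carbon can carry an amide linkage, with (2-methylphenyl)amino and its amide hydrogen in place of an aryl ketone, without a number appearing in this assay; its result is a limit of the assay. Set against the only numerical value in the series, the change gives an at least 1.7-fold higher number from compound 2 to compound 4 (0.25 log units; that floor lies within the scatter), so this floor does not establish a real difference, and the steps to compound 4 from compound 1 and compound 3 cannot be read. With the amide added, the picture at this position is still set mainly by the edge of the assay's range: the limit of > 100000 nM in this assay, at which 3 of the 4 values shown sit.

Compound 4 changes the linkage and the aryl group in a single step, so the compounds shown cannot separate the contribution of the amide from that of the 2-methylphenyl group, and they do not place compounds 1, 3 and 4 relative to one another. From the compounds shown here alone, it also remains open whether (3-bromophenyl)amino, or a carboxylic acid at this carbonyl carbon, would give a numerical value in this assay.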